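Swapping fluoro for chloro on the phenyl ring

The compounds below may be only part of what the source reports. "The series", "measured", "known", "first", "only" and "open" are said of these compounds alone.

- compound 1 `COc1cc2ncnc(Nc3cc(O)[nH]n3)c2cc1OC`: 86700 nM
- compound 2 `COc1cc2ncnc(Nc3cc(-c4ccccc4)[nH]n3)c2cc1OC`: < 100000 nM (a limit)
- compound 3 `COc1cc2ncnc(Nc3cc(-c4ccc(F)cc4)[nH]n3)c2cc1OC`: < 100000 nM (a limit)

All three compounds share one core and were tested in a functional assay on MDA-MB-468 cells (Homo sapiens) for cytotoxicity, read by MTT assay; a lower number here means a stronger inhibitor, a higher number a weaker inhibitor. Only compound 1 has a true number there, 86700 nM. Compound 2 has only a limit, < 100000 nM. Compound 3 also has only a limit, < 100000 nM. This is the limit of < 100000 nM in this assay, at which 2 of the 3 values shown sit, so the standing of compound 3 is not known exactly.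

The next compound is compound 4 `COc1cc2ncnc(Nc3cc(-c4ccc(Cl)cc4)[nH]n3)c2cc1OC`. It differs from compound 3 in a single place: chloro in place of fluoro on an aromatic carbon. The change turns 4-fluorophenyl into 4-chlorophenyl.

The closest measured change is at that same place, and it gives a step that the two limits leave unreadable from compound 2 to compound 3. The two changes away from the hydroxy compound give a step that the limit leaves unreadable from compound 1 to compound 2 and a step that the limit leaves unreadable from compound 1 to compound 3. None of these has a size to carry over, so no step beyond the usual scatter is expected in this assay, and no direction can be given. The estimated change is a step that the limit leaves unreadable from compound 3 to compound 4. Going by the values given here, the only firm number to work from is that of compound 1, 86700 nM, so the range stays wide. For compound 4 the expected value is 50000 nM, within an estimated range of 12000 nM to 100000 nM.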

Compound 4, half-maximal inhibitory concentration: 79500 nM
Compound 4: middle estimate off by 1.6-fold (0.20 log units), on the low side; the measured number falls inside the stated range.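

In this assay the 4-chlorophenyl group gives this position its first ring-bearing substituent with a true number rather than a limit. That makes one direct comparison with the hydroxy group possible, and exchanging hydroxy for 4-chlorophenyl gives a 1.1-fold lower number from compound 1 to compound 4 (0.04 log units; within the scatter) in this assay, so even this large change of group leaves no readable difference. The steps that compare chloro with fluoro or with hydrogen on the phenyl ring cannot be read, because each of them rests on a value that is only a limit: the limit of < 100000 nM in this assay, at which 2 of the 4 values shown sit.

From the compounds shown here alone, the effect of chloro in place of fluoro therefore remains unknown, and these compounds cannot show whether any substituent on the phenyl ring matters in this assay at all. Also open, going by these compounds, is what an amine or a carboxylic acid on that ring would do, or a longer chain in place of the ring, and whether any such group would bring a step beyond the scatter.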